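Swapping a Fluorophenyl for a Hydroxy-Methoxyphenyl Group

The source may hold more compounds than are shown below. What is called first, only, known or untested is meant among the compounds shown, and "the series" means these compounds.

Within the data shown here, compound 3 `O=C1/C(=C/c2ccc(F)cc2)C=C(c2ccc(Cl)cc2)N1Cc1ccccc1` gives 89.5% in a functional assay on the whole organism (strain Wistar) for inhibition, with Rattus norvegicus as the target, with stated times of 30 min and 3 h, at a dose of 20 mg/kg by the oral route (on this read-out lower numbers stand for less inhibition and higher numbers for more inhibition at the one dose given (going by the name of the read-out)), the highest of the three numbers measured so far; compound 2 `O=C1/C(=C/c2ccc(Cl)cc2)C=C(c2ccc(Cl)cc2)N1Cc1ccccc1` gives 88.9%, which lies within the usual scatter of compound 3, while compound 1 `O=C1/C(=C/c2ccccc2)C=C(c2ccc(Cl)cc2)N1Cc1ccccc1` gives 37%. Compound 4 `COc1cc(/C=C2\C=C(c3ccc(Cl)cc3)N(Cc3ccccc3)C2=O)ccc1O` differs from compound 3 in one place: 4-hydroxy-3-methoxyphenyl in place of 4-fluorophenyl on a double-bonded chain carbon bound to a double-bonded ring carbon. Among the measured compounds shown here, two measured steps touch this position. Putting chloro or fluoro in place of hydrogen gave large gains, a number 51.9 percentage points higher from compound 1 to compound 2 (beyond the scatter) and a number 52.5 percentage points higher from compound 1 to compound 3 (beyond the scatter), whereas exchanging the two halogens changed little, a number 0.6 percentage points higher from compound 2 to compound 3 (within the scatter). For the measured compounds named here, no measured step tests a hydroxy- and methoxy-bearing ring, so the expectation is wide. The step of a number 24.5 percentage points lower from compound 3 to compound 4 (beyond the scatter) is expected to be a moderate drop. Compound 4 is therefore estimated at 65%, most likely between 35% and 90%.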

Compound 4, a percentage reported as inhibition, in the whole organism at one dose (the size of the read-out at that dose, not a potency): 42%
Estimate against measurement, compound 4: 23 percentage points above; the range from low to high includes it.
By their numbers in this assay, from the lowest: compounds 1 and 4 (each within the scatter of the next); then compounds 2 and 3 (each within the scatter of the next).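

The 4-hydroxy-3-methoxyphenyl group does not share the gain of the halogen-bearing rings at this place, with a number 47.5 percentage points lower from compound 3 to compound 4 (beyond the scatter) and a number 46.9 percentage points lower from compound 2 to compound 4 (beyond the scatter) in the same read-out. Against the plain phenyl ring there is a number 5 percentage points higher from compound 1 to compound 4 (within the scatter) so a substituted ring does not by itself give a high number here. Nothing available accounts for this loss.

On these data alone, whether a ring bearing the hydroxy alone or the methoxy alone would resemble compound 3 or compound 4 stays open. So does the effect of an amine or a carboxylic acid on this ring.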